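Para-substituted benzamides on the chromone-ether anilide core

The compounds below may be only part of what the source reports. "The series", "measured", "known", "first", "only" and "open" are said of these compounds alone.

Two members of the series have numbers in an assay on isolated protein for inhibition of Rho-associated protein kinase 2 (Homo sapiens), read by scintillation counting, radiometric assay and 33P incorporation, with a stated time of 40 min, in the presence of a further agent that is not named here; on this read-out lower numbers stand for stronger inhibition and higher numbers for weaker inhibition. Compound 1 `Cc1ccc(C(=O)Nc2cccc(NC(=O)COc3ccc4c(=O)ccoc4c3)c2)cc1` gives 22 nM. Among the measured compounds shown here, compound 2 `N#Cc1ccc(C(=O)Nc2cccc(NC(=O)COc3ccc4c(=O)ccoc4c3)c2)cc1` gives 15 nM; the single step of a 1.5-fold lower number from compound 1 to compound 2 (0.17 log units; within the scatter) is within the scatter, so the two numbers cannot be ordered. Compound 2 carries the lowest of the two numbers, with compound 1 as its nearest neighbour at a separation that is within the scatter.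

Compound 3 `CCOc1ccc(C(=O)Nc2cccc(NC(=O)COc3ccc4c(=O)ccoc4c3)c2)cc1` has not yet been measured in this assay. It differs from compound 2 in one place: ethoxy in place of cyano on an aromatic carbon. For the measured compounds named here, the only measured step bears on the same position, the exchange of methyl for cyano from compound 1 to compound 2, and it stayed within the scatter. Going by the values given here, no measured step exchanges cyano for an ethoxy group, so the expectation rests on that one step and on the shared core that is otherwise unchanged. The step of a 1.5-fold higher number from compound 2 to compound 3 (0.17 log units; within the scatter) is therefore expected to be small and not clearly beyond the scatter in either direction. For compound 3 the expected number in this assay is 22 nM, with a range from 8 nM to 60 nM.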

Compound 3, half-maximal inhibitory concentration: 9 nM
Estimate against measurement, compound 3: 2.4-fold (0.39 log units) above; low and high end bracket the measured number.
By their numbers in this assay, from the lowest: compounds 3, 2 and 1 (each within the scatter of the next, the first and the last beyond it).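

In this assay, among the compounds shown here, the step of a 2.4-fold lower number from compound 1 to compound 3 (0.39 log units; beyond the scatter) is the first at this position to lie beyond the scatter, so the group on this aromatic carbon, para to a large group, can move the number measurably, though only modestly. The step of a 1.7-fold lower number from compound 2 to compound 3 (0.22 log units; within the scatter) stays within the scatter, so ethoxy and cyano cannot be ordered here, even though the two groups share little beyond a single hydrogen-bond acceptor and no net charge: a triple bond leaves, and a group of 3 heavy atoms enters. Nothing available explains the separation between the methyl and ethoxy compounds.

From the compounds shown here alone, it remains open whether a longer chain such as butoxy, an amine or a carboxylic acid at the same place would take the number further from that of compound 3 or return it towards that of compound 1. Also open, going by these compounds, is whether the ether oxygen or the two-carbon chain accounts for the difference from methyl, a question that a methoxy group at this position would begin to separate.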